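The compounds below may be only part of what the source reports. "The series", "measured", "known", "first", "only" and "open" are said of these compounds alone.

Measured so far in a functional assay on SEM cells (Homo sapiens) for cytotoxicity, with a stated time of 72 h; a lower number here means that less compound is needed, a higher number that more compound is needed for the effect:
Compound 1 `C=C[C@@](C)(/C=C/c1ccc(OC)cc1)CCC=C(C)C`: > 36600 nM
Compound 2 `C=C[C@@](C)(/C=C/c1ccc(OS(=O)(=O)C(F)(F)F)cc1)CCC=C(C)C`: > 36600 nM
Compound 3 `C=C[C@@](C)(/C=C/c1ccc(Nc2ccc(OC)cc2)cc1)CCC=C(C)C`: > 36600 nM

Compound 3 stands at > 36600 nM, and this is a limit of the assay, not a number. The other two entries are limits too, so the whole set rests on (the limit of > 36600 nM in this assay, at which 3 of the 3 values shown sit).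

Compound 4 `C=C[C@@](C)(/C=C/c1ccc(Nc2ccc(OC)c(F)c2)cc1)CCC=C(C)C` differs from compound 3 in one place: fluoro in place of hydrogen on an aromatic carbon. In words, this is fluoro in place of hydrogen on an aromatic carbon, turning 4-methoxyphenyl into 3-fluoro-4-methoxyphenyl.

The measured steps are a step that the two limits leave unreadable from compound 1 to compound 2, a step that the two limits leave unreadable from compound 1 to compound 3 and a step that the two limits leave unreadable from compound 2 to compound 3. None of them has a readable size, and none places a fluoro on an aromatic carbon, so they give no size or direction to carry over. Going by the values given here, the only anchor is therefore compound 3, with its limit of > 36600 nM.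

The expected outcome is no change beyond the scatter, with a step that the limit leaves unreadable from compound 3 to compound 4 as the estimated step in this assay. For compound 4 the estimate is 40000 nM, with an expected range from 18000 nM to 80000 nM.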

Compound 4, half-maximal effective concentration: > 36600 nM
Compound 4 gave a limit, no number; the forecaster's own chance of this, stated with the estimate: 80%; the middle value is on the limit's open side.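

Compound 4 gives > 36600 nM and this is a limit, not a number. Compound 3 also stands at a limit, so no size can be read for the step between compound 3 and compound 4. The compounds shown leave open whether any of these changes alters the effect in this assay, since all of them rest on one limit: the limit of > 36600 nM in this assay, at which 4 of the 4 values shown sit.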